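Primary amide to hydroxycyclohexyl amide: notes on compound 3

The compounds below may be only part of what the source reports. "The series", "measured", "known", "first", "only" and "open" are said of these compounds alone.

Compound 2 `Cc1cc(C(N)=O)nn1Cc1cc(Cl)cc2cc(-c3ccccc3)oc12` is the primary amide of the series. In an assay on CHO-K1 cells for displacement of a labelled ligand from prostaglandin E2 receptor EP1 subtype (Homo sapiens), read by scintillation counting, with a stated time of 45 min (on this read-out higher numbers stand for weaker inhibition and lower numbers for stronger inhibition), compound 2 gives 5.01 nM, the only number shown so far. Compound 1 `Cc1cc(C(=O)O)nn1Cc1cc(Cl)cn2nc(C(C)C)cc12`, an acid on a different core, gives in this assay only a limit, > 1000 nM. Among the measured compounds shown here, it sits at the limit of > 1000 nM in this assay, at which 1 of the 2 values shown sits, so no measured step exists, and the size of any change on the amide must be estimated without precedent.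

Compound 3 `Cc1cc(C(=O)N[C@H]2CC[C@H](O)CC2)nn1Cc1cc(Cl)cc2cc(-c3ccccc3)oc12` differs from compound 2 by 4-hydroxycyclohexyl in place of hydrogen on an amide-type nitrogen. Converting the primary amide to a secondary amide of this kind is expected to cost little, with a small weakening in this assay that may stay within the scatter. The expected step is a 2.4-fold higher number from compound 2 to compound 3 (0.38 log units; beyond the scatter). Compound 3 is therefore estimated at 12 nM, with a range from 3 nM to 60 nM.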

Compound 3, half-maximal inhibitory concentration: 7.94 nM
Estimate against measurement, compound 3: 1.5-fold (0.18 log units) above; measured number inside the range.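

In this assay, among the compounds shown here, the amide-type nitrogen takes 4-hydroxycyclohexyl in place of hydrogen with a 1.6-fold higher number from compound 2 to compound 3 (0.20 log units; within the scatter), the first measured step. Substitution at this nitrogen is therefore compatible with strong inhibition, even with a six-membered non-aromatic ring of carbon only, and compound 2 and compound 3 cannot be told apart on this read-out. Nothing shown explains this tolerance.

Still open, on these data alone, is whether a plain cyclohexyl group, a longer chain or an amine on the same nitrogen would read the same way, and whether the hydroxyl of the ring matters at all. As far as these compounds go, compound 1 gives > 1000 nM, which is a limit and not a number, and it differs from the other compounds in more than one place, so the effect of a carboxylic acid on the shared core also stays open.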